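Amide aryl variation on the shared core: ethyl for methoxy

The source may report more compounds than this note shows. Statements on the series, on what has been measured and on what is new or still open speak of the compounds shown alone.

Working notes on three measured amides and one still to be run. Compound 1 `COc1ccc(C(=O)Nc2cccc(-c3oc4cc(-c5ccc(F)cc5)ccc4c(=O)c3O)c2)cc1` gives the lowest of the three numbers in a functional assay on HepG2 cells (Homo sapiens) for antiproliferative activity, read by CCK-8 assay, with a stated time of 72 h (a lower number here means a stronger inhibitor, a higher number a weaker inhibitor), at 8420 nM. In this assay compound 3 `COc1ccccc1C(=O)Nc1cccc(-c2oc3cc(-c4ccc(F)cc4)ccc3c(=O)c2O)c1` gives 14500 nM, and compound 2 `O=C(Nc1cccc(-c2oc3cc(-c4ccc(F)cc4)ccc3c(=O)c2O)c1)c1ccc(F)cc1F` gives 26400 nM. The step of a 1.7-fold higher number from compound 1 to compound 3 (0.24 log units; within the scatter) sits within the scatter, the step of a 3.1-fold higher number from compound 1 to compound 2 (0.50 log units; beyond the scatter) lies beyond it, and a 1.8-fold lower number from compound 2 to compound 3 (0.26 log units; within the scatter) is again within it. Compound 4 `CCc1ccc(C(=O)Nc2cccc(-c3oc4cc(-c5ccc(F)cc5)ccc4c(=O)c3O)c2)cc1` differs from compound 1 by ethyl in place of methoxy on an aromatic carbon. Among the compounds with values here, none of the measured steps touches this change: all three vary the aryl on the carbonyl carbon in other ways, and even the largest of them is only modest. With nothing in the measured set that bears on an ethyl for a methoxy, a number close to that of compound 1 is expected, without a step beyond the scatter. For compound 4 the estimated step is a 1.1-fold higher number from compound 1 to compound 4 (0.03 log units; within the scatter). Compound 4 is therefore expected at 9000 nM, within a range from 3500 nM to 25000 nM.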

Compound 4, half-maximal inhibitory concentration: 20600 nM
The estimate for compound 4 lay 2.3-fold (0.36 log units) below the measured number; measured number inside the range.
By their numbers in this assay, from the lowest: compounds 1, 3, 4 and 2 (each within the scatter of the next, the first and the last beyond it).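

In this assay, the carbon para to a large group on the amide aryl is sensitive to this exchange: ethyl in place of methoxy gives a 2.4-fold higher number from compound 1 to compound 4 (0.39 log units; beyond the scatter), a modest step but one that shows the two groups are not interchangeable here. The 4-ethylphenyl amide also falls in with the other two amides, with a 1.4-fold higher number from compound 3 to compound 4 (0.15 log units; within the scatter) and a 1.3-fold lower number from compound 2 to compound 4 (0.11 log units; within the scatter), both within the scatter, so a single replacement at this position is enough to lose the separation of compound 1 from compound 2. No measurement at hand accounts for the step.

Open, on these data alone, is how a hydroxyl, an ethoxy or a dimethylamino group on the same carbon would read against compound 1. Also open, as far as these compounds go, is whether the step tracks the oxygen of methoxy or the group as a whole.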